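Pyridinyl swap on a piperazine in an aminothiophene series

This account rests on a few compounds, and the source may have more. Where it says the series, first, only, none or still open, it means among the compounds named here.

Of the compounds shown here, two have been measured in a functional assay on CHO cells with adenosine receptor A1 (Homo sapiens) as the target, read by cAMP accumulation and immunoassay, with a stated time of 6 min, tested at 0.1 uM; a higher number here means a weaker effect of the compound at the concentration tested, a lower number a stronger effect. Compound 1 `Nc1scc(CN2CCN(c3ccc(F)cc3Cl)CC2)c1C(=O)c1ccc(Cl)cc1` gives -6.2% in this assay. Compound 2 `Nc1scc(CN2CCN(c3cccnc3)CC2)c1C(=O)c1ccc(Cl)cc1` gives 3.4% in this assay. The two sit within the scatter of one another: the step of a number 9.6 percentage points higher from compound 1 to compound 2 (within the scatter) does not exceed what repeated measurements of this kind vary by, so the replacement of 2-chloro-4-fluorophenyl by pyridin-3-yl on the amine nitrogen in the ring left the read-out where it was.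

Compound 3 `Nc1scc(CN2CCN(c3ccncc3)CC2)c1C(=O)c1ccc(Cl)cc1` differs from compound 2 in one place: pyridin-4-yl in place of pyridin-3-yl on an amine nitrogen in a ring. Within the data shown here, no measured step bears directly on the move from pyridin-3-yl to pyridin-4-yl, and the one step available was itself within the scatter. No step beyond the scatter is therefore expected for compound 3 in this assay, and compound 3 is expected to give about 3%, between -10% and 16%, an expected step of a number 0.4 percentage points lower from compound 2 to compound 3 (within the scatter).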

Compound 3, a percentage reported as activity, at one concentration (the size of the read-out at that concentration, not a potency): 1.4%
The estimate for compound 3 lay 1.6 percentage points above the measured number, and the stated range covers the measured number.
By their numbers in this assay, from the lowest: compounds 1, 3 and 2 (each within the scatter of the next).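

In this assay, exchanging pyridin-3-yl for pyridin-4-yl on the amine nitrogen in the ring gives a number 2 percentage points lower from compound 2 to compound 3 (within the scatter), so among these two pyridines the point of attachment made no difference that the read-out could separate, something the earlier pair could not show. Against the 2-chloro-4-fluorophenyl group, pyridin-4-yl gives a number 7.6 percentage points higher from compound 1 to compound 3 (within the scatter), so a second pyridine joins the first in leaving the read-out within the scatter of compound 1. Nothing available accounts for this flat response at the position.

On these data alone, it remains open whether pyridin-2-yl, a benzyl group or an acetyl group on this nitrogen would move the read-out beyond the scatter. These single-concentration numbers also leave open whether the three compounds would separate at any other concentration.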